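This account rests on a few compounds, and the source may have more. Where it says the series, first, only, none or still open, it means among the compounds named here.

Measured so far:
compound 1, `O=C(NCCO)c1cnc2ccccc2c1Cl`: > 100 uM
compound 2, `COC(=O)CNC(=O)c1cnc2ccccc2c1Cl`: > 100 uM

In an ADME assay on CCRF-CEM cells (Homo sapiens) for cytotoxicity (a lower number here means that less compound is tolerated, a higher number that more compound is tolerated), compound 1 gives > 100 uM, which is a limit of the assay and not a number. Compound 2 gives > 100 uM, again a limit. Within the data shown here, compound 1 therefore stands at a limit only, and the one further value shown is a limit too (the limit of > 100 uM in this assay, at which 2 of the 2 values shown sit). The step from compound 1 to compound 2, a step that the two limits leave unreadable from compound 1 to compound 2, cannot be read in size for that reason.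

Compound 3, `COC(=O)[C@H](CO)NC(=O)c1cnc2ccccc2c1Cl`, differs from compound 1 in one place: methoxycarbonyl in place of hydrogen on a saturated chain carbon bound to an amide-type nitrogen and a saturated chain carbon. Among the measured compounds shown here, the only measured step that bears on this change is the one from compound 1 to compound 2, which also brings in a methoxycarbonyl group, and its size is not readable. Within the scatter no step is expected in this assay, so the expected step is a step that the limit leaves unreadable from compound 1 to compound 3. Compound 3 is estimated at 150 uM, in the range 60 uM to 400 uM.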

Compound 3, half-maximal toxic concentration: > 100 uM
Compound 3: only a limit was reported (the forecaster's own chance of this, stated with the estimate: 70%); the middle value does not contradict the limit.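

Compound 3, like compound 1 and compound 2, gives only a limit and not a number, so no step among these three compounds can be read in size in this assay: the limit of > 100 uM in this assay, at which 3 of the 3 values shown sit. The compounds shown leave open how much compound these cells tolerate in each case, and whether the methoxycarbonyl or hydroxymethyl changes make any difference.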